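A Smaller Group on Compound 2 and Expected Solubility

The source may report more compounds than this note shows. Statements on the series, on what has been measured and on what is new or still open speak of the compounds shown alone.

Measured in a physicochemical assay for solubility, read by LC-MS, in phosphate buffer, with a stated time of 24 h, at pH 7.4; on this read-out lower numbers stand for lower solubility and higher numbers for higher solubility:
Compound 1 `CNC(=O)c1ccc(-c2cnc(NCc3c(F)ccc4c3CCO4)c3cn[nH]c(=O)c23)c(C)n1`: 19000 nM
Compound 2 `CNC(=O)c1ncc(-c2cnc(NCc3c(F)ccc4c3CCO4)c3cn[nH]c(=O)c23)n1C`: 5000 nM

For the measured compounds named here, compound 2 stands lowest of these two numbers; the one measured step is a 3.8-fold lower number from compound 1 to compound 2 (0.58 log units; beyond the scatter). Compound 3 `Cc1ncc(-c2cnc(NCc3c(F)ccc4c3CCO4)c3cn[nH]c(=O)c23)n1C` differs from compound 2 by methyl in place of methylcarbamoyl on an aromatic carbon. Going by the values given here, the measured step concerns a different change, so no measured step bears on this one, and the expectation rests on the change alone. Compound 3 is therefore expected to show a 1.3-fold lower number from compound 2 to compound 3 (0.10 log units; within the scatter), which is no step beyond the scatter. The estimate for compound 3 is 4000 nM, with a range from 1500 nM to 12000 nM.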

Compound 3, solubility: 15000 nM
For compound 3 the middle estimate is 3.8-fold (0.57 log units) below the measured one, and the stated range ends below it.
By their numbers in this assay, from the lowest: compound 2; then compounds 3 and 1 (each within the scatter of the next).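

In this assay, methyl in place of methylcarbamoyl on this aromatic carbon, between two ring nitrogen atoms, gives a 3.0-fold higher number from compound 2 to compound 3 (0.48 log units; beyond the scatter), so this position can shift the read-out beyond the scatter. Pairing 1,2-dimethyl-1H-imidazol-5-yl with the 2-methyl-6-(methylcarbamoyl)pyridin-3-yl group gives a 1.3-fold lower number from compound 1 to compound 3 (0.10 log units; within the scatter), so the five-membered ring does not always accompany the lower number. No measurement shown explains the step.

As far as these compounds go, it remains open how an amine, a carboxylic acid or a longer chain such as propyl would read at this carbon.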